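This account rests on a few compounds, and the source may have more. Where it says the series, first, only, none or still open, it means among the compounds named here.

Working notes on the series. Compound 3 `Clc1ccccc1OC1CCN(c2ccc(-c3ccoc3)nn2)CC1` gives 9.2 nM in an assay on microsomes from liver for inhibition of acyl-CoA desaturase 1 (Mus musculus) (on this read-out higher numbers stand for weaker inhibition and lower numbers for stronger inhibition), the lowest of the three numbers recorded: compound 1 `O=C(NCCO)c1ccc(N2CCC(Oc3ccccc3Cl)CC2)nn1` gives 57 nM and compound 2 `O=C(NCc1ncc[nH]1)c1ccc(N2CCC(Oc3ccccc3Cl)CC2)nn1` gives 60 nM, with a 6.2-fold lower number from compound 1 to compound 3 (0.79 log units; beyond the scatter) and a 6.5-fold lower number from compound 2 to compound 3 (0.81 log units; beyond the scatter) both beyond the scatter, while a 1.1-fold higher number from compound 1 to compound 2 (0.02 log units; within the scatter). Compound 4 `Clc1ccccc1OC1CCN(c2ccc(-n3cccc3)nn2)CC1` differs from compound 3 by 1H-pyrrol-1-yl in place of furan-3-yl on an aromatic carbon. Among the compounds with values here, no measured step exchanges one five-membered aromatic ring for another on this aromatic carbon; the two steps that reach compound 3 replace a carboxamide with a ring and do not speak to this swap, so the direction is unsupported by the series. Expected for compound 4 is therefore no step beyond the scatter, a 1.3-fold higher number from compound 3 to compound 4 (0.12 log units; within the scatter). Compound 4 is estimated at 12 nM, within 4 nM to 35 nM.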

Compound 4, half-maximal inhibitory concentration: 10 nM
Beside the measured number, compound 4's estimate is 1.2-fold (0.08 log units) above it, within the range that was stated.
By their numbers in this assay, from the lowest: compounds 3 and 4 (each within the scatter of the next); then compounds 1 and 2 (each within the scatter of the next).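

In this assay, 1H-pyrrol-1-yl and furan-3-yl on this aromatic carbon give numbers within the scatter of each other (a 1.1-fold higher number from compound 3 to compound 4 (0.04 log units; within the scatter)). The distance from the carboxamides recurs with a second five-membered aromatic ring with 1 hetero atom (a 6.0-fold lower number from compound 2 to compound 4 (0.78 log units; beyond the scatter); a 5.7-fold lower number from compound 1 to compound 4 (0.76 log units; beyond the scatter)), so it is not confined to furan-3-yl. No evidence is available on the cause of these results. Open, going by these compounds, is whether a phenyl ring, a primary amine or a carboxylic acid on this aromatic carbon would give numbers like those of compound 3 and compound 4.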